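Aryl-triazole variation on the spiro core: compound 4

The compounds below may be only part of what the source reports. "The series", "measured", "known", "first", "only" and "open" are said of these compounds alone.

Measured so far in a functional assay on HCT-116 cells (Homo sapiens) for antiproliferative activity, read by MTT assay, with a stated time of 48 h; on this read-out higher numbers stand for weaker inhibition and lower numbers for stronger inhibition:
- compound 1 `N#CC1=C(N)Oc2c(N)cc3nc4ccccc4nc3c2C12C(=O)N(Cc1cnnn1-c1cccc(Br)c1)c1ccccc12` gives 26100 nM
- compound 2 `N#CC1=C(N)Oc2c(N)cc3nc4ccccc4nc3c2C12C(=O)N(Cc1cnnn1-c1c(F)cccc1F)c1ccccc12` gives only a limit, > 50000 nM
- compound 3 `Cc1ccc(Cl)cc1-n1nncc1CN1C(=O)C2(C(C#N)=C(N)Oc3c(N)cc4nc5ccccc5nc4c32)c2ccccc21` gives 37200 nM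

Of the two numbers reported, compound 3 and compound 1 sit within the scatter of each other; their step, a 1.4-fold higher number from compound 1 to compound 3 (0.15 log units; within the scatter), is too small to rank them. Compound 2 stands at the limit of this assay the limit of > 50000 nM in this assay, at which 1 of the 3 values shown sits, and contributes a floor rather than a number.

Compound 4 `N#CC1=C(N)Oc2c(N)cc3nc4ccccc4nc3c2C12C(=O)N(Cc1cnnn1-c1c(Cl)cc(Cl)cc1Cl)c1ccccc12` differs from compound 3 only at the aryl group on the triazole nitrogen: 2,4,6-trichlorophenyl in place of 5-chloro-2-methylphenyl on an aromatic nitrogen.

Within the data shown here, three measured steps touch this position, and none rises above the scatter. Swapping 3-bromophenyl for 2,6-difluorophenyl gave an at least 1.9-fold higher number from compound 1 to compound 2 (0.28 log units; that floor lies within the scatter); swapping it for 5-chloro-2-methylphenyl gave a 1.4-fold higher number from compound 1 to compound 3 (0.15 log units; within the scatter); and moving from 2,6-difluorophenyl to 5-chloro-2-methylphenyl gave an at least 1.3-fold lower number from compound 2 to compound 3 (0.12 log units; that floor lies within the scatter). Among the measured compounds shown here, the series so far shows no aryl variant shifting this assay beyond its noise, so the expected step for compound 4 is small, with the open possibility of landing at the limit, as compound 2 did (the limit of > 50000 nM in this assay, at which 1 of the 3 values shown sits).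

Compound 4 is therefore estimated at 45000 nM, within a range of 20000 nM to 100000 nM. The step this estimate implies, a 1.2-fold higher number from compound 3 to compound 4 (0.08 log units; within the scatter), is expected to stay inside the scatter.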

Compound 4, half-maximal inhibitory concentration: 12100 nM
The estimate for compound 4 lay 3.7-fold (0.57 log units) above the measured number; the measured number lies below the stated range.
By their numbers in this assay, from the lowest: compound 4; then compounds 1 and 3 (each within the scatter of the next). At a limit, above all of these: compound 2.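

Unlike the steps among compounds 1, 2 and 3, the aryl group on the aromatic nitrogen now produces a measurable change in this assay: 2,4,6-trichlorophenyl in place of 5-chloro-2-methylphenyl gives a 3.1-fold lower number from compound 3 to compound 4 (0.49 log units; beyond the scatter), and in place of 3-bromophenyl it gives a 2.2-fold lower number from compound 1 to compound 4 (0.33 log units; beyond the scatter). Halogen on the aryl group is not enough by itself, as compounds 1, 2 and 3 all carry it, while 2,4,6-trichlorophenyl in place of 2,6-difluorophenyl gives an at least 4.1-fold lower number from compound 2 to compound 4 (0.61 log units; beyond the scatter), so compound 4 has the lowest number of the four. That last step is only a floor, and the value of compound 2 is a limit: the limit of > 50000 nM in this assay, at which 1 of the 4 values shown sits.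

The compounds shown cannot separate the number of chlorine atoms from their placement on the aryl group, as no pair here changes a single substituent on an otherwise identical aryl group. A 2,4-dichlorophenyl group would address that question directly, and an aryl group bearing an amine or a carboxylic acid would show whether anything other than halogen and methyl is tolerated at this position.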